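The compounds below may be only part of what the source reports. "The series", "measured", "known", "first", "only" and "open" are said of these compounds alone.

Measured compounds:
compound 1, `O=C(Nc1ccc(Cl)c(-c2nc3ccccc3[nH]2)c1)c1ccc(Br)o1`, gives 85 nM in an in vitro functional assay on HEK293-A cells for antagonist activity at metabotropic glutamate receptor 5 (Rattus norvegicus), read by calcium flux; a higher number here means a weaker inhibitor, a lower number a stronger inhibitor.
compound 2, `COc1ccccc1C(=O)Nc1cccc(NC(=O)c2ccc(Cl)cc2)c1`, returns only a limit, > 30000 nM, in this assay.

Compound 1 gives a measured number in this assay. For compound 2, by contrast, this assay reports no number but a limit, > 30000 nM, which places it at the limit of > 30000 nM in this assay, at which 1 of the 2 values shown sits. Going by the values given here, the two values show compound 1 well inside the measured range and compound 2 outside it; no step between them is given.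

Compound 3, `COc1ccccc1C(=O)Nc1cccc(NC(=O)c2ccc(F)cc2)c1`, is compound 2 with one change: fluoro in place of chloro on an aromatic carbon. Among the compounds with values here, no measured step bears on this exchange, so the expectation rests on compound 2 alone. Because compound 2 sits at the limit of > 30000 nM in this assay, at which 1 of the 2 values shown sits, compound 3 is expected to remain at or near the limit, a step that the limit leaves unreadable from compound 2 to compound 3 being no more than the scatter. Compound 3 is estimated at 50000 nM, within 15000 nM to 200000 nM.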

Compound 3, half-maximal inhibitory concentration: > 30000 nM
Compound 3: a limit, no number (the forecaster's own chance of this, stated with the estimate: 80%); the middle value does not contradict the limit.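

Compound 2 and compound 3 both return only a limit in this assay, so no step can be read for fluoro in place of chloro. The compounds shown leave open whether this exchange would alter the value of a compound with a measured number.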